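From a vinylphenyl to a thiazole side chain

This account rests on a few compounds, and the source may have more. Where it says the series, first, only, none or still open, it means among the compounds named here.

Three compounds have been measured in a functional assay on A549 cells (Homo sapiens) for cytotoxicity (a higher number here means that more compound is needed for the effect, a lower number that less compound is needed), so far:

- compound 1 `COC1=C(C)C(=O)/C(=C(O)/C=C/c2ccccc2OC)C(=O)C1(C)C` gives 2.4 ug/mL
- compound 2 `COC1=C(C)C(=O)/C(=C(O)/C=C/c2ccccc2C)C(=O)C1(C)C` gives 4.6 ug/mL
- compound 3 `C=Cc1ccccc1/C=C/C(O)=C1/C(=O)C(C)=C(OC)C(C)(C)C1=O` gives 2.2 ug/mL

Two steps place compound 3. The first is a 1.1-fold lower number from compound 1 to compound 3 (0.04 log units; within the scatter) and shows that these two compounds cannot be told apart. The second is a 2.1-fold lower number from compound 2 to compound 3 (0.32 log units; beyond the scatter) and is a modest but real difference. The remaining step is a 1.9-fold higher number from compound 1 to compound 2 (0.28 log units; within the scatter) and also stays inside the normal spread of repeat measurements.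

In compound 4 `COC1=C(C)C(=O)/C(=C(O)/C=C/c2nccs2)C(=O)C1(C)C` the shared core stays, and the change is 1,3-thiazol-2-yl in place of 2-vinylphenyl on a double-bonded chain carbon bound to a double-bonded chain carbon at that one place. This is a different kind of change from those measured so far. Each measured step swaps only a small group on an aromatic carbon, while here the whole ring is replaced. The measured steps therefore give a sense of scale but no direct guide, and they do not settle the direction. Even so, replacing the ring is a larger change than any of them, so a modest rise in the number in this assay seems more likely than a fall.

The expected step is a 2.3-fold higher number from compound 3 to compound 4 (0.36 log units; beyond the scatter) and is only a rough estimate. For compound 4 the estimated value is 5 ug/mL with an expected range from 1.8 ug/mL to 14 ug/mL in this assay.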

Compound 4, concentration for half-maximal effect: 3.5 ug/mL
Estimate against measurement, compound 4: 1.4-fold (0.15 log units) above; measured number inside the range.
By their numbers in this assay, from the lowest: compounds 3, 1, 4 and 2 (each within the scatter of the next, the first and the last beyond it).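

In this assay, for the compounds shown here, the earlier steps only swapped a small group on an aromatic carbon, whereas compound 4 replaces the whole ring on the double-bonded chain carbon bound to a double-bonded chain carbon, and the three comparisons read a 1.6-fold higher number from compound 3 to compound 4 (0.20 log units; within the scatter), a 1.3-fold lower number from compound 2 to compound 4 (0.12 log units; within the scatter) and a 1.5-fold higher number from compound 1 to compound 4 (0.16 log units; within the scatter). All three stay inside the normal spread of repeat measurements, so at this place a 1,3-thiazol-2-yl group, with its five-membered ring, nitrogen and sulfur, cannot be told apart in this assay from the 2-vinylphenyl, 2-methylphenyl or 2-methoxyphenyl group, each a six-membered ring of carbon only. No measurement at hand offers an explanation for this result.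

On these data alone, it remains open whether any aromatic ring is needed at this place, which a group such as a plain butyl chain, an amine or a carboxylic acid in the ring's stead would begin to answer. As far as these compounds go, it is also open whether the ring's nitrogen and sulfur matter for the number, a question that a comparison of the 1,3-thiazol-2-yl group with a 1,3-oxazol-2-yl, a thiophen-2-yl or an unsubstituted phenyl group could address.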